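Deacetylated thiadiazole glycoside with palmitoyl amide: cytotoxicity outlook

The source may hold more compounds than are shown below. What is called first, only, known or untested is meant among the compounds shown, and "the series" means these compounds.

Three compounds of the series carry a measured or reported cytotoxicity. Compound 1 `CCCCCCCCCCCCCC(=O)Nc1nnc(S[C@@H]2O[C@H](COC(C)=O)[C@H](OC(C)=O)[C@H](OC(C)=O)[C@H]2OC(C)=O)s1` gives 16300 nM in an ADME assay on CHO-K1 cells (Cricetulus griseus) for cytotoxicity, read by MTT assay, with a stated time of 24 h; a lower number here means a stronger inhibitor, a higher number a weaker inhibitor. Within the data shown here, compound 3 `CCCCCCCC/C=C\CCCCCCCCCCCC(=O)Nc1nnc(S[C@@H]2O[C@H](COC(C)=O)[C@H](OC(C)=O)[C@H](OC(C)=O)[C@H]2OC(C)=O)s1` gives 25200 nM in this assay; the only single-point step among the measured compounds is a 1.5-fold higher number from compound 1 to compound 3 (0.19 log units; within the scatter). Among the measured compounds shown here, compound 2 `CCCCCCCCCCCCCCCCCC(=O)Nc1nnc(S[C@@H]2O[C@H](CO)[C@H](O)[C@H](O)[C@H]2O)s1`, the deacetylated sugar with the longer saturated amide chain, stands apart: in this assay compound 2 is reported as "not active" (no number reported), with no number attached, so no step to it can be sized.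

Compound 4 `CCCCCCCCCCCCCCCC(=O)Nc1nnc(S[C@@H]2O[C@H](CO)[C@H](O)[C@H](O)[C@H]2O)s1` differs from compound 2 by hydrogen in place of ethyl on a saturated chain carbon, ten or more bonds along the chain from a carbonyl carbon. For the measured compounds named here, no measured step bears directly on this change; the one step available, between two acetylated compounds, stayed within the scatter. Going by the values given here, on the deacetylated core the only reference point is compound 2 without a number, so the expectation for compound 4 in this assay is of weak or no measurable inhibition, with a fair chance that only a limit is reported. The estimated value for compound 4 is 40000 nM, within a range from 15000 nM to 120000 nM.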

Compound 4, half-maximal inhibitory concentration: "not active" (no number reported)
Compound 4 has no reported number here; no gap can be computed for the estimate.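

Among these compounds, compound 2 and compound 4 are both reported as "not active" in this assay, with no number attached, so no step between them can be read. The compounds shown leave open how amide chain length bears on cytotoxicity on the deacetylated core. Nothing shown bears on this result.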